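The compounds below may be only part of what the source reports. "The series", "measured", "known", "first", "only" and "open" are said of these compounds alone.

Working notes on the series. Compound 1 `NS(=O)(=O)c1cccc(C(F)(F)F)c1` carries only the sulfonamide portion shared by the larger compounds; in an assay on HEK293 cells for inhibition of Voltage-dependent N-type calcium channel subunit alpha-1B (Homo sapiens), read by FLIPR and calcium flux (a higher number here means a weaker inhibitor, a lower number a stronger inhibitor), compound 1 reaches only a limit of > 10000 nM, as recorded in the limit of > 10000 nM in this assay, at which 1 of the 3 values shown sits. In this assay compound 2 `CS(=O)(=O)c1cc(C#N)ccc1C(=O)N1CCC(N(C2CC2)S(=O)(=O)c2cccc(C(F)(F)F)c2)CC1` gives 450 nM and compound 3 `CS(=O)(=O)c1ccc(Cl)c(C(=O)N2CCC(N(C3CC3)S(=O)(=O)c3cccc(C(F)(F)F)c3)CC2)c1` gives 340 nM. Going by the values given here, the single change between them, a 1.3-fold lower number from compound 2 to compound 3 (0.12 log units; within the scatter), stayed within the scatter. Compound 3 therefore holds the lowest of the two numbers, with compound 2 within the scatter of it.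

Compound 4 `CS(=O)(=O)c1ccc(C(=O)N2CCC(N(C3CC3)S(=O)(=O)c3cccc(C(F)(F)F)c3)CC2)c(Cl)c1` differs from compound 3 only in the arrangement of one aryl group: 2-chloro-4-(methylsulfonyl)phenyl in place of 2-chloro-5-(methylsulfonyl)phenyl on a carbonyl carbon. Among the compounds with values here, the one measured step that concerns a change of this aryl group on the carbonyl carbon, a 1.3-fold lower number from compound 2 to compound 3 (0.12 log units; within the scatter), was within the scatter, so no shift beyond the scatter is expected in this assay. The expected number for compound 4 is 400 nM, with a range from 150 nM to 1200 nM. The step this estimate implies is a 1.2-fold higher number from compound 3 to compound 4 (0.07 log units; within the scatter).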

Compound 4, half-maximal inhibitory concentration: 290 nM
Compound 4: middle estimate off by 1.4-fold (0.14 log units), on the high side; measured number inside the range.
By their numbers in this assay, from the lowest: compounds 4, 3 and 2 (each within the scatter of the next). At a limit, above all of these: compound 1.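

In this assay, 2-chloro-4-(methylsulfonyl)phenyl in place of 2-chloro-5-(methylsulfonyl)phenyl on the carbonyl carbon gives a 1.2-fold lower number from compound 3 to compound 4 (0.07 log units; within the scatter) for the same atoms joined differently. Set against 4-cyano-2-(methylsulfonyl)phenyl, the same group gives a 1.6-fold lower number from compound 2 to compound 4 (0.19 log units; within the scatter) and likewise stays inside the scatter, so the three aryl groups shown at this place cannot be told apart. Nothing measured here bears on a cause for these steps.

Still open, from the compounds shown here alone, is whether an aryl group carrying an amine or a carboxylic acid instead of methylsulfonyl would stay within this narrow band.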